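This account rests on a few compounds, and the source may have more. Where it says the series, first, only, none or still open, it means among the compounds named here.

In an assay on cells for agonist activity at ecdysone receptor (Bombyx mori), read by a luciferase reporter, with a stated time of 24 h (on this read-out lower numbers stand for an effect already at smaller amounts and higher numbers for an effect only at larger amounts of compound), compound 3, whose structure is `Cc1ccc(C(=O)NN(C(=O)c2ccccc2Cl)C(C)(C)C)cc1`, gives 18.6 nM, which puts it second highest among the three measured compounds. Its nearest neighbour is compound 2, drawn as `CC(C)(C)N(NC(=O)c1ccc(I)cc1)C(=O)c1ccccc1Cl`, which gives 7.59 nM, and the step between them is a 2.5-fold higher number from compound 2 to compound 3 (0.39 log units; beyond the scatter). Far away is compound 1, drawn as `CC(C)(C)N(NC(=O)c1ccccc1I)C(=O)c1ccccc1Cl`, which gives 1290 nM; from there the steps are a 170-fold lower number from compound 1 to compound 2 (2.23 log units; beyond the scatter) and a 69-fold lower number from compound 1 to compound 3 (1.84 log units; beyond the scatter). The next compound, compound 4, drawn as `Cc1cccc(C(=O)NN(C(=O)c2ccccc2Cl)C(C)(C)C)c1C`, carries the change (2,3-dimethylphenyl in place of 4-methylphenyl on a carbonyl carbon). Going by the values given here, the steps that bear on it are those leaving compound 1, where a group sitting on the 2-position of that ring went together with much higher numbers, while the modest step from compound 2 to compound 3 shows that a methyl on the 4-position keeps the number low. Compound 4 places methyl groups on the 2- and 3-positions and none on the 4-position, so the expected step is a 13-fold higher number from compound 3 to compound 4 (1.13 log units; beyond the scatter), toward higher numbers. Compound 4 is therefore estimated at 250 nM, within a range from 30 nM to 2000 nM.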

Compound 4, half-maximal effective concentration: 20 nM
The estimate for compound 4 lay 13-fold (1.10 log units) above the measured number, and the stated range ends above it.
By their numbers in this assay, from the lowest: compound 2; then compounds 3 and 4 (each within the scatter of the next); then compound 1.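

In this assay, putting 2,3-dimethylphenyl in place of 4-methylphenyl on a carbonyl carbon gives a 1.1-fold higher number from compound 3 to compound 4 (0.03 log units; within the scatter), so these two groups cannot be told apart here. The very high number of compound 1 therefore does not extend to every ring with a group at the 2-position, since 2,3-dimethylphenyl in place of 2-iodophenyl gives a 65-fold lower number from compound 1 to compound 4 (1.81 log units; beyond the scatter). Measured against 4-iodophenyl, the same group gives only a modest step, a 2.6-fold higher number from compound 2 to compound 4 (0.42 log units; beyond the scatter), so a low number here does not depend on having a 4-substituted ring.

Nothing available explains the wide gap between 2-iodophenyl and 2,3-dimethylphenyl. The compounds shown leave open how 2-methylphenyl alone, or a phenyl ring bearing an amine or a carboxylic acid, would compare.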